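The source may hold more compounds than are shown below. What is called first, only, known or untested is meant among the compounds shown, and "the series" means these compounds.

In a functional assay on the whole organism with Mus musculus as the target (a lower number here means that less compound is needed, a higher number that more compound is needed for the effect), compound 1 `Cc1cc2c(c(C)c1N)CC(C)(C)O2` gives 16.3 mg/kg and compound 2 `Cc1c(N)cc2c(c1C)OC(C)(C)C2` gives 24.4 mg/kg as its value, and these two numbers lie within the usual scatter of each other. On these data, then, compound 2 cannot be told apart from compound 1. Compound 3 `CC1(C)Cc2cc(N)ccc2O1` reads > 100 mg/kg as a limit of the assay and not as a number. Compound 4 `Cc1c(C)c2c(c(N)c1N)CC(C)(C)O2` differs from compound 2 in one place: amino in place of hydrogen on an aromatic carbon and this new amino group is ortho to an amino group and ortho to a fused ring. Among the compounds with values here, no measured pair here differs in one place only, so the effect of this change has not been seen directly. No shift beyond the scatter is therefore expected in this assay in either direction. The estimated 1.2-fold lower number from compound 2 to compound 4 (0.09 log units; within the scatter) is small. Compound 4 is expected at 20 mg/kg with an estimated range from 6 mg/kg to 70 mg/kg for now.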

Compound 4, dose for 50% inhibition: > 50 mg/kg
Compound 4 gave a limit, no number; the forecaster's own chance of this, stated with the estimate: 12%; at least 2.5-fold (0.39 log units) between middle value and limit.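

Within the data shown here, this is the first direct view of a change at this position, an aromatic carbon ortho to a fused ring and ortho to an amino group. In this assay, amino in place of hydrogen there gives an at least 2.0-fold higher number from compound 2 to compound 4 (0.31 log units; beyond the scatter), so more compound is needed for the effect and the added amino group does not leave the number unchanged. Only the smallest possible size of this step can be given, because the reading for compound 4 is a limit and not a number: the limit of > 50 mg/kg in this assay, at which 1 of the 4 values shown sits.

From the compounds shown here alone, the full size of the shift stays open, since the step has a lower bound and no upper one. It is also unclear whether the shift is specific to amino, as the compounds shown do not reveal how a hydroxyl group or a carboxylic acid on the same carbon would read.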